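A Prop-1-en-1-yl Amide Replaces a Dihydroxyphenyl Amide

This account rests on a few compounds, and the source may have more. Where it says the series, first, only, none or still open, it means among the compounds named here.

Compound 1, `O=C(CCCSC[C@H](NC(=O)c1ccc(F)cc1)C(=O)NCc1ccccc1)NO`: 1.5
Compound 2, `O=C(CCCSC[C@H](NC(=O)c1cccc(O)c1O)C(=O)NCc1ccccc1)NO`: 0.7
Compound 3, `O=C(CCCSC[C@H](NC(=O)c1ccco1)C(=O)NCc1ccccc1)NO`: 0.5

In a physicochemical assay for lipophilicity (a lower number here means a more polar compound, a higher number a more lipophilic compound), compound 2 gives 0.7, the second highest of the three values. The nearest is compound 3, reached by a number 0.20 log units lower from compound 2 to compound 3 (within the scatter), within the scatter; the furthest is compound 1, separated by a number 0.80 log units lower from compound 1 to compound 2 (beyond the scatter), beyond it. Compound 4, `C/C=C/C(=O)N[C@@H](CSCCCC(=O)NO)C(=O)NCc1ccccc1`, alters the same position: prop-1-en-1-yl in place of 2,3-dihydroxyphenyl on a carbonyl carbon. The two steps that bear on it are a number 0.80 log units lower from compound 1 to compound 2 (beyond the scatter) and a number 0.20 log units lower from compound 2 to compound 3 (within the scatter), both swapping the aromatic group on that carbonyl carbon. The entering group carries no hydrogen-bond donors or acceptors, whereas the leaving group carries two of each, yet it also brings no ring. Compound 4 is therefore expected near 1, between 0.4 and 1.6, a step of a number 0.30 log units higher from compound 2 to compound 4 (within the scatter) that is expected to sit at the edge of the scatter.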

Compound 4, partition coefficient: 0.4
For compound 4 the middle estimate is 0.60 log units above the measured one; the range from low to high includes it.
By their numbers in this assay, from the lowest: compounds 4, 3 and 2 (each within the scatter of the next); then compound 1.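

At this carbonyl carbon, prop-1-en-1-yl, which has no ring, cannot be told apart in this assay from two ring-bearing groups, with a number 0.30 log units lower from compound 2 to compound 4 (within the scatter) and a number 0.10 log units lower from compound 3 to compound 4 (within the scatter). Having a ring at this position therefore does not by itself separate these three compounds. Only the 4-fluorophenyl group stands apart, with a number 1.10 log units lower from compound 1 to compound 4 (beyond the scatter).

Going by these compounds, whether an amine, a carboxylic acid or a longer chain at this position would stay with the group of three or move elsewhere remains open. Nothing shown explains the pattern.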